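The source may hold more compounds than are shown below. What is called first, only, known or untested is meant among the compounds shown, and "the series" means these compounds.

Working notes on the series in this assay, a functional assay on A549 cells (Homo sapiens) for inhibition, read by MTT assay, with a stated time of 72 h; a higher number here means a weaker inhibitor, a lower number a stronger inhibitor.

Three compounds carry a number. Compound 1 `CN(C(=O)NC(=O)c1ccc(F)c(F)c1)c1nc(C(F)(F)F)c(C(=O)N/N=C/c2ccc(C(F)(F)F)cc2)s1` gives 6.07 ug/mL. Compound 2 `CN(C(=O)NC(=O)c1ccc(F)c(F)c1)c1nc(C(F)(F)F)c(C(=O)N/N=C/c2ccccc2C(F)(F)F)s1` gives 6.96 ug/mL, the highest of the three numbers, but the step of a 1.1-fold higher number from compound 1 to compound 2 (0.06 log units; within the scatter) and the step of a 1.2-fold lower number from compound 2 to compound 3 (0.08 log units; within the scatter) both sit within the scatter, so compound 2 is not separated from either neighbour. Compound 3 `CN(C(=O)NC(=O)c1ccc(F)c(F)c1)c1nc(C(F)(F)F)c(C(=O)N/N=C/c2ccc([N+](=O)[O-])cc2)s1` gives 5.78 ug/mL; the step of a 1.1-fold lower number from compound 1 to compound 3 (0.02 log units; within the scatter) is likewise within the scatter.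

Compound 4 `CN(C(=O)NC(=O)c1ccccc1F)c1nc(C(F)(F)F)c(C(=O)N/N=C/c2ccccc2C(F)(F)F)s1` is not yet measured. It differs from compound 2 in one place: 2-fluorophenyl in place of 3,4-difluorophenyl on a carbonyl carbon. None of the three measured steps touches this part of the molecule; all three exchange the aryl group on the carbon with a double bond to nitrogen, and each of them stayed within the scatter. The data therefore give no direct guide for a change at the carbonyl carbon, and the only observation available is that the series has so far moved little.

On that basis the step of a 1.0-fold higher number from compound 2 to compound 4 (0.00 log units; within the scatter) is expected to be none beyond the scatter. Compound 4 is estimated at 7 ug/mL, with a range from 3.5 ug/mL to 14 ug/mL.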

Compound 4, half-maximal inhibitory concentration: 6.32 ug/mL
The estimate for compound 4 lay 1.1-fold (0.04 log units) above the measured number; low and high end bracket the measured number.
By their numbers in this assay, from the lowest: compounds 3, 1, 4 and 2 (each within the scatter of the next).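

In this assay, within the data shown here, the step of a 1.1-fold lower number from compound 2 to compound 4 (0.04 log units; within the scatter) is the first one read at the carbonyl carbon whose other neighbour is the amide-type nitrogen, and it shows that this position, not only the aryl group on the carbon with a double bond to nitrogen, can change without separating two compounds. Exchanging 3,4-difluorophenyl for 2-fluorophenyl removes one fluorine and moves the remaining count of heavy atoms by that atom alone, yet compound 4 stays unseparated from compound 2. No measurement at hand offers an explanation for this result.

On these data alone, whether any group at the carbonyl carbon gives a step beyond the scatter stays open, as only fluorinated phenyl groups stand there; a longer alkyl chain, or a phenyl ring bearing an amine or a carboxylic acid, would test it. Also open, as far as these compounds go, is whether the same exchange reads alike with 4-nitrophenyl on the carbon with a double bond to nitrogen.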